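Weak Cytotoxicity across Piperazinyl Triazines: Compound 3 to Compound 4

The compounds below may be only part of what the source reports. "The series", "measured", "known", "first", "only" and "open" are said of these compounds alone.

Measured compounds:
compound 1 `O=C(CN1CCN(c2cccc(Cl)c2)CC1)N1CCN(c2nnc(-c3ccccc3)c(-c3ccccc3)n2)CC1`: 178000 nM
compound 2 `COc1ccc(N2CCN(CC(=O)N3CCN(c4nnc(-c5ccc(C)cc5)c(-c5ccc(C)cc5)n4)CC3)CC2)cc1`: 116000 nM
compound 3 `COc1ccc(-c2nnc(N3CCN(C(=O)CN4CCN(c5cccc(OC)c5)CC4)CC3)nc2-c2ccc(OC)cc2)cc1`: > 821000 nM

In an ADME assay on NIH3T3 cells (Mus musculus) for cytotoxicity, read by MTT assay, with a stated time of 24 h (a higher number here means a weaker inhibitor, a lower number a stronger inhibitor), compound 1 gives 178000 nM and compound 2 gives 116000 nM. For compound 3 this assay reports only a limit, > 821000 nM. Compound 3 therefore stands at the limit of > 821000 nM in this assay, at which 1 of the 3 values shown sits; its true value is not known, only that it lies beyond this limit.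

Compound 4 `COc1ccc(-c2nnc(N3CCN(C(=O)CN4CCN(c5ccc([N+](=O)[O-])cc5)CC4)CC3)nc2-c2ccc(OC)cc2)cc1` differs from compound 3 in one place: 4-nitrophenyl in place of 3-methoxyphenyl on an amine nitrogen in a ring. Within the data shown here, no pair of measured compounds differs in a single place, so no measured step is available to gauge this change. Compound 4 is expected to remain a weak inhibitor in this assay, with an expected step of an at least 1.1-fold lower number from compound 3 to compound 4 (0.06 log units; that floor lies within the scatter) from the limit of compound 3, within the scatter. Compound 4 is estimated at 700000 nM, in a range from 250000 nM to 1500000 nM.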

Compound 4, half-maximal inhibitory concentration: > 801000 nM
Compound 4 gave a limit, no number (the forecaster's own chance of this, stated with the estimate: 50%); middle value at least 1.1-fold (0.05 log units) from the limit.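

Among these compounds, compound 3 and compound 4 each give only a limit in this assay, so no step between them can be read. The compounds shown leave open whether 4-nitrophenyl in place of 3-methoxyphenyl shifts the true value at all.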